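Amino to Isothiocyanate on the Aryl Triazole Tail

The source may report more compounds than this note shows. Statements on the series, on what has been measured and on what is new or still open speak of the compounds shown alone.

For the measured compounds named here, compound 1 `CNC(=O)[C@@]12C[C@@H]1[C@@H](n1cnc3c(NCc4cccc(Cl)c4)nc(C#CCCCCc4cn(-c5ccc(N)cc5)nn4)nc31)[C@H](O)[C@@H]2O` stands as the lower of the two numbers measured so far in an assay on CHO cells for displacement of a labelled ligand from adenosine receptor A3 (Homo sapiens), read by scintillation counting; on this read-out higher numbers stand for weaker inhibition and lower numbers for stronger inhibition. In this assay, going by the values given here, compound 1 gives 87.1 nM, while compound 2 `CNC(=O)[C@@]12C[C@@H]1[C@@H](n1cnc3c(NCc4cccc(Cl)c4)nc(C#CCCCCc4cn(CCCCCCC(=O)NCCOCOCOCOCNC5SCC6NC(=O)NC65)nn4)nc31)[C@H](O)[C@@H]2O`, which carries a different substituent on the triazole, gives 235 nM; the gap between these two lies beyond the scatter, and no single-point step connects them.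

Compound 3 `CNC(=O)[C@@]12C[C@@H]1[C@@H](n1cnc3c(NCc4cccc(Cl)c4)nc(C#CCCCCc4cn(-c5ccc(N=C=S)cc5)nn4)nc31)[C@H](O)[C@@H]2O` is the direct neighbour of compound 1. The change is a group of 3 heavy atoms (1 carbon, 1 nitrogen, 1 sulfur; no ring) in place of one nitrogen atom, on an aromatic carbon, in words a group of 3 heavy atoms (1 carbon, 1 nitrogen, 1 sulfur; no ring) in place of one nitrogen atom, on an aromatic carbon, para to a large group on the six-membered carbon-only aromatic ring.

Among the compounds with values here, since no measured pair in this set shares this change, the step size must be estimated from the structures alone; the replacement is expected to move this assay by little, with no direction beyond the scatter favoured. The step from compound 1 to compound 3 is expected to be a 1.1-fold higher number from compound 1 to compound 3 (0.06 log units; within the scatter). Compound 3 is therefore estimated at 100 nM, within a range from 30 nM to 330 nM.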

Compound 3, inhibition constant: 37.5 nM
Beside the measured number, compound 3's estimate is 2.7-fold (0.43 log units) above it; measured number inside the range.
By their numbers in this assay, from the lowest: compound 3; then compound 1; then compound 2.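

The aryl group on the triazole tail proves responsive to a change in one place: in this assay, replacing the amino group with isothiocyanate, on an aromatic carbon para to a large group, gives a 2.3-fold lower number from compound 1 to compound 3 (0.37 log units; beyond the scatter), a modest step but one beyond the scatter. For the compounds shown here, the earlier pair could not show this, as compound 1 and compound 2 differ in the whole substituent on the triazole and no single-point step connects them. The count of hydrogen-bond donors falls from 1 in the amino group to 0 in the entering group, and hydrogen-bond acceptors rise from 1 to 2, but no measurement here links the step to either count or to any other property of the two groups.

A single step leaves open whether the lower number is particular to isothiocyanate or would also appear with another group at this place, such as a nitro group, an acetamide or a thiourea. It also leaves open how an unsubstituted phenyl ring would compare with compound 1 and compound 3.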